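Rearranging the lactam ring of a butenolide-lactam chain

The source may report more compounds than this note shows. Statements on the series, on what has been measured and on what is new or still open speak of the compounds shown alone.

Compound 1 `CC1=C(O)[C@H](C/C(C)=C\CC[C@H](C)/C=C/C=C(\C)CCCC2=CCN(CCC(C)C)C2=O)OC1=O`: 4.1 ug/mL
Compound 2 `CCC(C)CN1CC=C(CCC/C(C)=C/C=C/[C@@H](C)CC/C=C(/C)C[C@@H]2OC(=O)C(C)=C2O)C1=O`: 3.8 ug/mL

In a functional assay on SK-MEL-2 cells (Homo sapiens) for cytotoxicity (on this read-out lower numbers stand for an effect already at smaller amounts and higher numbers for an effect only at larger amounts of compound), compound 2 has the lowest of the two numbers, with compound 1 within the scatter of it. Compound 3 `CC1=C(O)[C@H](C/C(C)=C\CC[C@H](C)/C=C/C=C(\C)CCCC2=CC(=O)N(CCC(C)C)C2)OC1=O` differs from compound 2 by a group of 11 heavy atoms (9 carbon, 1 nitrogen, 1 oxygen; one five-membered non-aromatic ring with 1 hetero atom) in place of a group of 11 heavy atoms (9 carbon, 1 nitrogen, 1 oxygen; one five-membered non-aromatic ring with 1 hetero atom), on a saturated chain carbon, three bonds along the chain from a double-bonded chain carbon. Among the compounds with values here, only one measured step bears on this: a 1.1-fold lower number from compound 1 to compound 2 (0.03 log units; within the scatter), which covers the chain on the nitrogen but not the rejoining of the ring. Nothing measured addresses the ring change, so the step of a 1.2-fold higher number from compound 2 to compound 3 (0.07 log units; within the scatter) is expected to stay within the scatter. Compound 3 is therefore estimated at 4.5 ug/mL, between 2 ug/mL and 10 ug/mL.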

Compound 3, concentration for half-maximal effect: 13.2 ug/mL
Compound 3: middle estimate off by 2.9-fold (0.47 log units), on the low side; the measured number lies above the stated range.
By their numbers in this assay, from the lowest: compounds 2 and 1 (each within the scatter of the next); then compound 3.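

Joining the same atoms differently within the five-membered ring changes the read-out in this assay more than the earlier change to the chain on the nitrogen did, giving a 3.2-fold higher number from compound 1 to compound 3 (0.51 log units; beyond the scatter) and a 3.5-fold higher number from compound 2 to compound 3 (0.54 log units; beyond the scatter). The ring attached at this saturated chain carbon therefore matters in its exact arrangement, even though the counted atoms and ring size stay the same. Nothing available explains this rise. Still open, from the compounds shown here alone, is whether the ring is needed at all, or whether an open-chain amide or a carboxylic acid at this place would give a lower or higher number.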